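Inverting one ring stereocentre: expected stability of compound 3

The source may report more compounds than this note shows. Statements on the series, on what has been measured and on what is new or still open speak of the compounds shown alone.

compound 1 `O=C(O)[C@H](CO)NC(=O)[C@H]1C[C@H](O)CN1` gives > 12 h as a limit
compound 2 `O=C(N[C@H](CO)C(=O)O)[C@@H]1C[C@H](O)CN1` gives > 12 h as a limit
compound 3 `O=C(N[C@H](CO)C(=O)O)[C@@H]1C[C@@H](O)CN1` is not yet measured

In an ADME assay on Caco-2 cells (Homo sapiens) for metabolic stability, read by HPLC, with a stated time of 12 h (a higher number here means that the compound lasts longer, a lower number that the compound disappears faster), compound 2 gives > 12 h as a limit and not a number. Compound 2 shares this position with compound 1 (the limit of > 12 h in this assay, at which 2 of the 2 values shown sit) so the two cannot be ranked. The change to compound 3 is one of configuration only (the two compounds have the same atoms and bonds and differ only in configuration as drawn: 1 of 3 stereo elements differ; a stereocentre at a saturated ring carbon is drawn S in compound 2 and R in compound 3). Going by the values given here, the only measured step bearing on it (a step that the two limits leave unreadable from compound 1 to compound 2) also alters configuration alone (the fact that compounds 1 and 2 differ only in the configuration as drawn) and has no readable size. No step beyond the scatter is therefore expected in this assay and no direction can be assigned. For compound 3 the estimated half-life is 16 h with an expected range from 9 h to 30 h and another limit is the likeliest report. This estimate means an expected step (a step that the limit leaves unreadable from compound 2 to compound 3) of no clear direction.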

Compound 3, half-life: > 12 h
Compound 3: a limit, no number; the forecaster's own chance of this, stated with the estimate: 80%; the middle value lies beyond the limit too.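

In this assay compound 1, compound 2 and compound 3 all give a limit and not a number, so no step among them can be read: the limit of > 12 h in this assay, at which 3 of the 3 values shown sit.

The compounds shown leave open whether any change of configuration among them alters the half-life at all.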